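The compounds below may be only part of what the source reports. "The series", "measured", "known", "first", "only" and "open" are said of these compounds alone.

Compound 1 `CCCCCc1ccc(-c2cn(C[C@H](O)[C@H]3OC(=O)C(OCc4ccccc4)=C3OCc3ccccc3)nn2)cc1` is examined in a functional assay on HepG2 cells (Homo sapiens) for antiproliferative activity, read by MTT assay, with a stated time of 72 h (on this read-out higher numbers stand for weaker inhibition and lower numbers for stronger inhibition), where compound 1 gives 7460 nM. Among the results shown it is the only one reported as a number. Compound 2 `O=C1O/C(=C\Cn2cc(-c3cc(C(F)(F)F)cc(C(F)(F)F)c3)nn2)C(OCc2ccccc2)=C1OCc1ccccc1` is recorded in this assay only as a limit, > 100000 nM. Compound 3 `COc1ccccc1-c1cn(C/C=C2\OC(=O)C(OCc3ccccc3)=C2OCc2ccccc2)nn1` likewise yields in this assay only a limit, > 100000 nM. Two of the three results therefore sit at the limit of > 100000 nM in this assay, at which 2 of the 3 values shown sit, so compound 1 stands alone with a measured number. Compound 4 `O=C1O[C@H]([C@@H](O)Cn2cc(CCCCl)nn2)C(OCc2ccccc2)=C1OCc1ccccc1` has not yet been tested in this assay. Among the compounds with values here, it differs from compound 1 in one place: 3-chloropropyl in place of 4-pentylphenyl on an aromatic carbon No pair of measured compounds differs in a single place, so no measured step can be set beside this change. The account must rest on compound 1 alone and on the fact that the other two compounds reach only limits. In this assay compound 4 is expected to give 30000 nM, with a range from 8000 nM to 100000 nM. That estimate means a step of a 4.0-fold higher number from compound 1 to compound 4 (0.60 log units; beyond the scatter), toward weaker inhibition and beyond the usual scatter, with a real chance that only a limit is reported.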

Compound 4, half-maximal inhibitory concentration: 35000 nM
Compound 4: the middle estimate sits 1.2-fold (0.07 log units) below what was measured; measured number inside the range.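

In this assay 3-chloropropyl in place of 4-pentylphenyl on an aromatic carbon of the five-membered aromatic ring with 3 nitrogen gives a 4.7-fold higher number from compound 1 to compound 4 (0.67 log units; beyond the scatter) toward weaker inhibition, the first sign that this position responds to the group it carries. The step is modest, and compound 4, whose group has no ring, still inhibits at a level that can be given as a number. Compound 4 therefore does not join the compounds reported only as a limit: the limit of > 100000 nM in this assay, at which 2 of the 4 values shown sit.

One step cannot separate the loss of the six-membered aromatic ring from the shorter chain or the entry of chlorine, and a plain propyl chain, a longer alkyl chain or an amine at this carbon would bear on that question. On these data alone, whether a phenyl ring with a shorter alkyl group or with a methoxy group would keep the inhibition of compound 1 also stays open.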